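Shortening the Butyl Chain of Compound 3

The source may report more compounds than this note shows. Statements on the series, on what has been measured and on what is new or still open speak of the compounds shown alone.

Of the compounds shown here, three sharing one core have been tested in a toxicity assay on HEK-293T cells (Homo sapiens) for cytotoxicity, read by MTT assay, with a stated time of 72 h; a higher number here means a weaker inhibitor, a lower number a stronger inhibitor. There, compound 1 `O=C1c2c[n+]([O-])c3ccccc3c2C(=O)c2c1c1ccccc1n2CCCCn1ccnc1` gives 280 nM, compound 2 `O=C1c2c[n+]([O-])c3ccccc3c2C(=O)c2c1c1ccccc1n2Cc1cn(C[C@H](O)CO)nn1` gives 8880 nM, and compound 3 `CN1CCN(CCCCn2c3c(c4ccccc42)C(=O)c2c[n+]([O-])c4ccccc4c2C3=O)CC1` gives 100 nM, the lowest of the three numbers.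

Compound 4 `CN1CCN(CCCn2c3c(c4ccccc42)C(=O)c2c[n+]([O-])c4ccccc4c2C3=O)CC1` differs from compound 3 in one place: 4-(4-methylpiperazin-1-yl)butyl becomes 3-(4-methylpiperazin-1-yl)propyl, (4-methylpiperazin-1-yl in place of (4-methylpiperazin-1-yl)methyl on a saturated chain carbon, three bonds along the chain from an aromatic nitrogen). The change falls on a saturated chain carbon, three bonds along the chain from an aromatic nitrogen.

For the measured compounds named here, no measured step changes only the chain length, so the evidence is indirect. Swapping the end group on the same chain gave a modest step, a 2.8-fold lower number from compound 1 to compound 3 (0.45 log units; beyond the scatter). Replacing the whole side chain gave a large one, an 89-fold lower number from compound 2 to compound 3 (1.95 log units; beyond the scatter). Compound 4 keeps the 4-methylpiperazin-1-yl group, so its change is narrower than either of these.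

The expected result is a 1.3-fold higher number from compound 3 to compound 4 (0.11 log units; within the scatter), although the data do not establish a direction. The estimate for compound 4 is 130 nM, with an expected range from 45 nM to 380 nM.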

Compound 4, half-maximal inhibitory concentration: 170 nM
Beside the measured number, compound 4's estimate is 1.3-fold (0.12 log units) below it, and the stated range covers the measured number.
By their numbers in this assay, from the lowest: compounds 3, 4 and 1 (each within the scatter of the next, the first and the last beyond it); then compound 2.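

In this assay, taking one carbon out of the chain, so that 4-(4-methylpiperazin-1-yl)butyl becomes 3-(4-methylpiperazin-1-yl)propyl, gives a 1.7-fold higher number from compound 3 to compound 4 (0.23 log units; within the scatter) and so leaves the two compounds indistinguishable. Against the other side chains, the result holds only in part: a 52-fold lower number from compound 2 to compound 4 (1.72 log units; beyond the scatter) remains a large step, while a 1.6-fold lower number from compound 1 to compound 4 (0.22 log units; within the scatter) no longer clears the scatter, unlike the step from compound 1 to compound 3. No measurement shown here explains these steps.

Still open, as far as these compounds go, is how the number moves with a shorter 2-(4-methylpiperazin-1-yl)ethyl chain or with a chain longer than butyl. It is also unclear whether chain length would matter as little with a different end group on the same chain, such as morpholine or a primary amine.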